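Working notes: from benzyloxy to phenoxy on compound 2

A few compounds are considered here, and "the series" means these few. Any claim that something is new, unique, unknown or untested is made for them only; others in the source may bear on it.

In an ADME assay on BHK-21 cells (Mesocricetus auratus) for cytotoxicity, read by MTT assay, with a stated time of 72 h (a lower number here means that less compound is tolerated, a higher number that more compound is tolerated), compound 1 (`Cc1cccc(C2CC(c3ccc(Oc4ccccc4)cc3)=NN2c2ccc(S(N)(=O)=O)cc2)c1`) gives 8000 nM as its value and compound 2 (`Cc1ccc(C2CC(c3ccc(OCc4ccccc4)cc3)=NN2c2ccc(S(N)(=O)=O)cc2)cc1`) gives 32000 nM as its value. Compound 2 therefore holds the higher of the two numbers, and the gap between them lies beyond the usual scatter. Going by the values given here, these two numbers are all that exist so far, and no measured pair differs in one place only.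

Compound 3 (`Cc1ccc(C2CC(c3ccc(Oc4ccccc4)cc3)=NN2c2ccc(S(N)(=O)=O)cc2)cc1`) follows from compound 2 with phenyl in place of benzyl on an oxygen on an aromatic ring. The same difference reads benzyloxy to phenoxy.

Among the compounds with values here, no measured step shows what this change does on its own, so the expectation is weakly grounded. Compound 1, which also carries a phenoxy group, gives 8000 nM in this assay and so points to a downward move of moderate size, near the edge of the scatter. The expected step (a 2.3-fold lower number from compound 2 to compound 3 (0.36 log units; beyond the scatter)) rests on that single value. For compound 3 an estimate of 14000 nM is expected, with 6000 nM to 32000 nM as the estimated range.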

Compound 3, half-maximal cytotoxic concentration: 8000 nM
For compound 3 the middle estimate is 1.8-fold (0.24 log units) above the measured one, and the stated range covers the measured number.
By their numbers in this assay, from the lowest: compounds 1 and 3 (each within the scatter of the next); then compound 2.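

In this assay, going by these compounds alone, the change from benzyloxy to phenoxy now has a reading of its own, with only this group differing: a 4.0-fold lower number from compound 2 to compound 3 (0.60 log units; beyond the scatter), so phenyl in place of benzyl on this oxygen goes with less compound being tolerated. The swap of 4-methylphenyl in place of 3-methylphenyl on a saturated ring carbon gives no change at the digits printed from compound 1 to compound 3 (within the scatter), which leaves the benzyloxy to phenoxy change as the only single-place step beyond the scatter among these three compounds. No data on hand bear on what lies behind the step from benzyl to phenyl.

Going by these compounds, each change has been read only once and on a single background, so it remains open whether the benzyloxy to phenoxy step would have the same size with 3-methylphenyl on the saturated ring carbon. On these data alone, it is also open how this assay would respond to other groups on this oxygen, such as phenethyl as a longer chain or a plain methyl, and therefore whether the reading follows the length of the group or applies only to this pair.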